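This account rests on a few compounds, and the source may have more. Where it says the series, first, only, none or still open, it means among the compounds named here.

Three compounds in this series keep the shared core and vary the pendant aryl group. Compound 1 `COc1ccccc1-c1cccc(COc2ccc(S(=O)(=O)CC(=O)O)cc2)c1` gives 195 nM in a functional assay on CHO cells for agonist activity at Free fatty acid receptor 1 (Homo sapiens), read by FLIPR and calcium flux; a higher number here means that more compound is needed for the effect, a lower number that less compound is needed. Compound 2 `Cc1nc(-c2cccc(F)c2)sc1COc1ccc(S(=O)(=O)CC(=O)O)cc1` gives 275 nM in this assay, and compound 3 `Cc1nc(-c2ccc(F)cc2)sc1COc1ccc(S(=O)(=O)CC(=O)O)cc1` gives 191 nM. Among the compounds with values here, the one single-point step among them, a 1.4-fold lower number from compound 2 to compound 3 (0.16 log units; within the scatter), lies within the scatter. Compound 3 carries the lowest number of the three, but its gaps to compound 1 and to compound 2 are both within the scatter, so no order among the three compounds can be read from these numbers.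

Compound 4 `Cc1cccc(-c2nc(C)c(COc3ccc(S(=O)(=O)CC(=O)O)cc3)s2)c1` differs from compound 3 by 3-methylphenyl in place of 4-fluorophenyl on an aromatic carbon. Within the data shown here, only the step from compound 2 to compound 3 bears on this change, as the sole measured case of a substituent change on the same pendant phenyl ring, and that step was within the scatter; no measured pair exchanges fluorine for methyl, so the effect of that exchange is unknown here. The expectation for the step from compound 3 to compound 4 is therefore a 1.1-fold higher number from compound 3 to compound 4 (0.04 log units; within the scatter), with no movement beyond the scatter. Compound 4 is estimated at 210 nM in this assay, with a range from 90 nM to 480 nM.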

Compound 4, half-maximal effective concentration: 214 nM
For compound 4 the middle estimate is 1.0-fold (0.01 log units) below the measured one; the range from low to high includes it.
By their numbers in this assay, from the lowest: compounds 3, 1, 4 and 2 (each within the scatter of the next).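

In this assay, the exchange of fluorine for methyl on the pendant phenyl ring now has a measured case (a 1.3-fold lower number from compound 2 to compound 4 (0.11 log units; within the scatter)), so 3-fluorophenyl and 3-methylphenyl cannot be told apart on this aromatic carbon, next to the ring nitrogen and the ring sulfur. The change that alters both the substituent and its place on the phenyl ring (a 1.1-fold higher number from compound 3 to compound 4 (0.05 log units; within the scatter)) is also within the scatter, so 4-fluorophenyl and 3-methylphenyl cannot be told apart either. All three steps among compound 2, compound 3 and compound 4 now lie within the scatter, but no available measurement bears on why these substituent changes leave the number so little moved.

The compounds shown leave open whether 4-methylphenyl at this position would also stay within the scatter of compound 3 and compound 4, which would separate the effect of the substituent from that of its place on the ring. They also leave open whether an amine, a carboxylic acid or a longer chain such as butyl on the pendant phenyl ring would move the number beyond the scatter.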